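Nitro to dimethylamino swap carried onto a second core

The source may report more compounds than this note shows. Statements on the series, on what has been measured and on what is new or still open speak of the compounds shown alone.

Compound 1, `N#Cc1cccc(S(=O)(=O)Oc2ccc(-c3cncn3C3CCN(C(=O)c4ccc([N+](=O)[O-])cc4)CC3)cc2)c1`, gives 13 nM in an assay on THP-1 cells for antagonist activity at P2X purinoceptor 7 (Homo sapiens), read by ELISA, with a stated time of 30 min; on this read-out lower numbers stand for stronger inhibition and higher numbers for weaker inhibition.
Compound 2, `CN(C)c1ccc(C(=O)N2CCC(n3cncc3-c3ccc(OS(=O)(=O)c4cccc(C#N)c4)cc3)CC2)cc1`, gives 10 nM in this assay.
Compound 3, `O=C(c1ccc([N+](=O)[O-])cc1)N1CCC(c2nc3cc(OS(=O)(=O)c4cccc5cnccc45)ccc3[nH]2)CC1`, gives 17 nM in this assay.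

Compound 1 and compound 3 are built from the same atoms joined differently; the difference between the two cores is not broken down here. Their values in this assay sit within the scatter of each other, as do those of compound 3 and compound 2.

On the core of compound 1 the change dimethylamino in place of nitro on an aromatic carbon produced a 1.3-fold lower number from compound 1 to compound 2 (0.11 log units; within the scatter).

Compound 4, `CN(C)c1ccc(C(=O)N2CCC(c3nc4cc(OS(=O)(=O)c5cccc6cnccc56)ccc4[nH]3)CC2)cc1`, carries the same change on the core of compound 3: dimethylamino in place of nitro on an aromatic carbon. The two descriptions of the place agree word for word, so this is the same change on a different core.

The step is expected to be a 1.3-fold lower number from compound 3 to compound 4 (0.12 log units; within the scatter) in this assay, resting on the single earlier occurrence, a 1.3-fold lower number from compound 1 to compound 2 (0.11 log units; within the scatter), and on the value of compound 3, 17 nM. On these data alone, whether the change behaves alike on both cores is untested.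

Compound 4 is estimated at 13 nM, with the expected range 5 nM to 35 nM.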

Compound 4, half-maximal inhibitory concentration: 121 nM
The estimate for compound 4 lay 9.3-fold (0.97 log units) below the measured number; the whole stated range lies below it.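

Dimethylamino in place of nitro on an aromatic carbon does not carry over unchanged between these two cores in this assay; on the second core it gives a 7.1-fold higher number from compound 3 to compound 4 (0.85 log units; beyond the scatter). Set beside the earlier step, the two outcomes differ: the same change on two cores in this assay, a 1.3-fold lower number (0.11 log units; within the scatter) from compound 1 to compound 2 and a 7.1-fold higher number (0.85 log units; beyond the scatter) from compound 3 to compound 4, 9.3-fold (0.97 log units) apart, beyond the scatter of two such steps. This shows that the size and direction of the step depend on the core for this one pair of cores, but it does not show which feature of the cores is responsible, and two occurrences give no rule for a further core.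

Open, on these data alone, is how other groups at the same place on the core of compound 3, such as a primary amine or a carboxylic acid, compare with nitro and dimethylamino.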